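This account rests on a few compounds, and the source may have more. Where it says the series, first, only, none or still open, it means among the compounds named here.

In an ADME assay on BJ cells (Homo sapiens) for cytotoxicity, read by MTT assay, with a stated time of 72 h (on this read-out lower numbers stand for higher toxicity in this test and higher numbers for lower toxicity in this test), compound 1, whose structure is `OC[C@H]1O[C@@H](n2cc(Cl)c3c(-c4ccco4)ncnc32)[C@H](O)[C@@H]1O`, gives 37300 nM. Compound 2, with the structure `OC[C@H]1O[C@@H](n2cc(Cl)c3c(-c4ccoc4)ncnc32)[C@H](O)[C@@H]1O`, is its partner in a single change, (furan-3-yl in place of furan-2-yl on an aromatic carbon), and in this assay compound 2 gives 21600 nM. The step is a 1.7-fold lower number from compound 1 to compound 2 (0.24 log units; within the scatter).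

Compound 3 has the structure `CCCCCCCCCCCCCCCCCCOP(=O)(O)OC[C@H]1O[C@@H](n2ccc3c(-c4ccco4)ncnc32)[C@H](O)[C@@H]1O`. Its core differs from that of compound 1 in a way that is not broken down here. For compound 3 this assay gives only a limit, > 50000 nM, and it is the sole one of the three to sit at the limit of > 50000 nM in this assay, at which 1 of the 3 values shown sits.

Compound 4, with the structure `CCCCCCCCCCCCCCCCCCOP(=O)(O)OC[C@H]1O[C@@H](n2ccc3c(-c4ccoc4)ncnc32)[C@H](O)[C@@H]1O`, has not been measured. It stands to compound 3 as compound 2 stands to compound 1, through the same change, (furan-3-yl in place of furan-2-yl on an aromatic carbon), set at the same place.

The step expected in this assay is a number no higher from compound 3 to compound 4 (the limit leaves the size open), resting on the earlier pairing, where the step of a 1.7-fold lower number from compound 1 to compound 2 (0.24 log units; within the scatter) stayed within the scatter. On that basis compound 4 is estimated at 50000 nM, with a range expected from 25000 nM to 100000 nM, and a limit rather than a number is the likelier report.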

Compound 4, half-maximal cytotoxic concentration: 44200 nM
The estimate for compound 4 lay 1.1-fold (0.05 log units) above the measured number, within the range that was stated.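

Carried to the core of compound 3, furan-3-yl in place of furan-2-yl gives, in this assay, an at least 1.1-fold lower number from compound 3 to compound 4 (0.05 log units; that floor lies within the scatter). The figure for compound 3 is a limit, > 50000 nM, so this step has only a floor and no measured size. The two pairs therefore give no sign that the change acts differently on the two cores, but they do not show that it carries over with the same size: the same change on two cores in this assay, a 1.7-fold lower number (0.24 log units; within the scatter) from compound 1 to compound 2 and an at least 1.1-fold lower number (0.05 log units; that floor lies within the scatter) from compound 3 to compound 4; the limit leaves it open whether they differ

The compounds shown leave open whether a group other than the two furans, such as a phenyl group or an amine on the same aromatic carbon, would give a step beyond the scatter on either core. They also leave open whether a shorter chain on the phosphate would give numbers clear of the limit, so that the step could be read in full.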